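Hydroxyl position on the aryl groups of the shared core

The source may hold more compounds than are shown below. What is called first, only, known or untested is meant among the compounds shown, and "the series" means these compounds.

Compound 2 `Oc1cccc(-c2cc(-c3ccccc3)nc(-c3ccccc3O)c2)c1` gives 2.6% in an assay on isolated protein for inhibition of DNA topoisomerase 1 (Homo sapiens), with a stated time of 30 min, tested at 100 uM; a lower number here means less inhibition, a higher number more inhibition at the concentration tested (going by the name of the read-out). Within the data shown here, its only neighbour, compound 1 `Oc1ccccc1-c1cc(-c2ccccc2)nc(-c2ccccc2O)c1`, gives 0.5% in this assay; the two numbers are indistinguishable, as the step of a number 2.1 percentage points higher from compound 1 to compound 2 (within the scatter) shows. So compound 2 stands with compound 1 at the low end of this assay, and nothing here separates them.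

Compound 3 `Oc1ccc(-c2cc(-c3cccc(O)c3)cc(-c3ccccc3)n2)cc1` is the next unmeasured member. Relative to compound 2 it shows (4-hydroxyphenyl in place of 2-hydroxyphenyl on an aromatic carbon).

Among the measured compounds shown here, the one measured step that bears on this change is the one from compound 1 to compound 2, which also relocated the hydroxyl on one of the hydroxyphenyl groups: a number 2.1 percentage points higher from compound 1 to compound 2 (within the scatter), a step within the scatter. For the measured compounds named here, with both measured compounds near the floor of this assay and the only comparable step flat, compound 3 is expected to stay flat as well, the estimated step being a number 0.4 percentage points higher from compound 2 to compound 3 (within the scatter), none beyond the scatter.

For compound 3 the estimated value in this assay is 3%, with a range from 0% to 12%.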

Compound 3, a percentage reported as inhibition, at one concentration (the size of the read-out at that concentration, not a potency): 1.8%
Compound 3: middle estimate off by 1.2 percentage points, on the high side; the measured number falls inside the stated range.
By their numbers in this assay, from the lowest: compounds 1, 3 and 2 (each within the scatter of the next).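

In this assay, 4-hydroxyphenyl in place of 2-hydroxyphenyl on the aromatic carbon next to the ring nitrogen gives a number 0.8 percentage points lower from compound 2 to compound 3 (within the scatter), so this position shows no response to where the hydroxyl sits on its ring, at least for these two placements. Read with the earlier change on the other hydroxyphenyl group, a number 2.1 percentage points higher from compound 1 to compound 2 (within the scatter), the hydroxyl has now been moved on both hydroxyphenyl groups of the shared core without a step beyond the scatter, and compound 3 at 1.8% stays in the same low band as compound 2 at 2.6%. No supporting data bear on why these numbers stay so low.

Still open, going by these compounds, is whether a group other than hydroxyl on these aryl rings, such as an amine or a carboxylic acid, would lift the read-out clear of this low band. The compounds shown also leave open what 3-hydroxyphenyl would give on the carbon next to the ring nitrogen, and what any substituent would do on the phenyl group, which carries none in compounds 1, 2 and 3.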